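Three Flat Aryl Swaps Point to a Fourth

The source may report more compounds than this note shows. Statements on the series, on what has been measured and on what is new or still open speak of the compounds shown alone.

Compounds measured so far:
- compound 1, `O=S(=O)(NCCCNCc1cccc2ccccc12)c1cc(C(F)(F)F)cc(C(F)(F)F)c1`: 2800 nM
- compound 2, `O=S(=O)(NCCCNCc1ccc(Cl)cc1)c1cc(C(F)(F)F)cc(C(F)(F)F)c1`: 2800 nM
- compound 3, `COc1ccc(CNCCCNS(=O)(=O)c2cc(C(F)(F)F)cc(C(F)(F)F)c2)cc1OC`: 2800 nM

All three share one core and differ only in the aryl group on a saturated chain carbon bound to an amine nitrogen. In a functional assay on MIA PaCa-2 cells (Homo sapiens) for inhibition, read by MTT assay, with a stated time of 72 h (a higher number here means a weaker inhibitor of growth, a lower number a stronger inhibitor of growth), compound 1 gives 2800 nM, compound 2 gives 2800 nM, and compound 3 gives 2800 nM. The steps between them are no change at the digits printed from compound 1 to compound 2 (within the scatter), no change at the digits printed from compound 1 to compound 3 (within the scatter) and no change at the digits printed from compound 2 to compound 3 (within the scatter); compound 3 therefore stands level with compound 1 and compound 2 in this assay.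

Compound 4, `CC(C)(C)c1ccc(CNCCCNS(=O)(=O)c2cc(C(F)(F)F)cc(C(F)(F)F)c2)cc1`, continues this series of aryl swaps. The change from compound 3 is 4-(tert-butyl)phenyl in place of 3,4-dimethoxyphenyl on a saturated chain carbon bound to an amine nitrogen, which, cut one bond further out, reads 3,4-dimethoxybenzyl to 4-(tert-butyl)benzyl. The three measured steps each exchanged this aryl group, and none moved the read-out beyond the scatter. Nothing in the data separates one aryl group from another, so the expectation for compound 4 is a step of no change at the digits printed from compound 3 to compound 4 (within the scatter), that is, none beyond the scatter. Compound 4 is accordingly estimated at 2800 nM in this assay, with a range from 1400 nM to 5600 nM.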

Compound 4, concentration for 50% growth inhibition: 2300 nM
The estimate for compound 4 lay 1.2-fold (0.09 log units) above the measured number, within the range that was stated.
By their numbers in this assay, from the lowest: compounds 4, 1, 2 and 3 (each within the scatter of the next).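

In this assay, the 4-(tert-butyl)phenyl group brings a branched saturated carbon substituent onto the aromatic ring, a kind of group that the naphthalen-1-yl, 4-chlorophenyl and 3,4-dimethoxyphenyl groups did not offer at this place, on a saturated chain carbon bound to an amine nitrogen. The exchange for naphthalen-1-yl gives a 1.2-fold lower number from compound 1 to compound 4 (0.09 log units; within the scatter) and tert-butyl in place of chloro on an aromatic carbon gives a 1.2-fold lower number from compound 2 to compound 4 (0.09 log units; within the scatter) while the exchange of a group with 2 hydrogen-bond acceptors for one with 0 gives a 1.2-fold lower number from compound 3 to compound 4 (0.09 log units; within the scatter) so that all four aryl groups, whether of carbon only or carrying chlorine or oxygen, read alike in this series. No measurement is available that would explain this sameness.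

All four compounds carry an uncharged aryl group of carbon-only rings at this place, which leaves open how a pyridine ring, a carboxylic acid on the aromatic ring or a cyclohexyl group in place of the aryl group would read. On these data alone, they also share one core, so what a longer chain between its two nitrogens, or a single trifluoromethyl group on its aromatic ring, would do remains open.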